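A few compounds are considered here, and "the series" means these few. Any claim that something is new, unique, unknown or untested is made for them only; others in the source may bear on it.

Compound 1 `O=C(Nc1cc(-c2nc3ccccc3s2)ccc1Cl)c1cc([N+](=O)[O-])ccc1Cl` was tested in an ADME assay on HepG2 cells (Homo sapiens) for cytotoxicity, with a stated time of 72 h; on this read-out lower numbers stand for an effect already at smaller amounts and higher numbers for an effect only at larger amounts of compound. In that assay compound 1 gave only a limit, > 25000 nM, and not a number. Two further compounds were measured alongside it. Compound 2 `Cc1ccc(-c2nc3ccccc3s2)cc1NC(=O)c1cc([N+](=O)[O-])c(N2CCCCC2)cc1Cl` also gave only a limit in this assay, > 25000 nM. Compound 3 `O=C(Nc1cc(-c2nc3ccccc3o2)ccc1F)c1cc([N+](=O)[O-])ccc1Cl` likewise reached only the limit, > 25000 nM. For the measured compounds named here, all three measured values thus sit at the same point, (the limit of > 25000 nM in this assay, at which 3 of the 3 values shown sit), and no step between them can be counted; compound 1 stands exactly where the other two stand.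

Compound 4 `O=C(Nc1cccc(-c2nc3ccccc3s2)c1)c1cc([N+](=O)[O-])ccc1Cl` has not yet been measured. It differs from compound 1 in one place: hydrogen in place of chloro on an aromatic carbon. The chloro group leaves and a hydrogen enters on an aromatic carbon of a six-membered aromatic ring of carbon only, while the rest of compound 1 stays as it is.

With every measured value at the limit, there is no measured step to lean on, and nothing among these compounds points to a move beyond the scatter in this assay. The expected step is a number no higher from compound 1 to compound 4 (the limit leaves the size open). Compound 4 is therefore estimated at about 25000 nM in this assay, with a range from 12000 nM to 50000 nM, and most probably again reported only as a limit.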

Compound 4, half-maximal effective concentration: > 27000 nM
Compound 4: only a limit was reported; the forecaster's own chance of this, stated with the estimate: 85%; middle value at least 1.0-fold (0.03 log units) from the limit.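

For the compounds shown here, compound 1 and compound 4 each gave only a limit in this assay, so no step from compound 1 to compound 4 can be read. The compounds shown leave open at what amount, if any, each would reach the half-maximal effect, and whether hydrogen in place of chloro alters it.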